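Pentyloxy in place of pyrrolidin-1-yl: cytotoxicity notes

This account rests on a few compounds, and the source may have more. Where it says the series, first, only, none or still open, it means among the compounds named here.

In an ADME assay on HFF cells (Homo sapiens) for cytotoxicity, with a stated time of 8 days (a lower number here means that less compound is tolerated, a higher number that more compound is tolerated), compound 2 `Nc1nc(N2CCCC2)c2ncn(/C=C3/CC3(CO)CO)c2n1` gives > 300000 nM, which is a limit and not a number. Compound 1 `Nc1nc(OCC(F)(F)F)c2ncn(/C=C3/CC3(CO)CO)c2n1` gives > 300000 nM, which is also a limit. Among the compounds with values here, the only measured step is a step that the two limits leave unreadable from compound 1 to compound 2, so it offers no size to carry forward. The whole evidence is the limit of > 300000 nM in this assay, at which 2 of the 2 values shown sit.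

Compound 3 `CCCCCOc1nc(N)nc2c1ncn2/C=C1/CC1(CO)CO` is not yet measured. It differs from compound 2 as follows: pentyloxy in place of pyrrolidin-1-yl on an aromatic carbon. Within the data shown here, the new group sits on the same aromatic carbon, and no measured compound here carries pentyloxy. Among the measured compounds shown here, no measured step therefore sets a size or direction, and the expectation in this assay is for no change beyond the scatter, with some room for a lower value. The expected step is an at least 1.3-fold lower number from compound 2 to compound 3 (0.13 log units; that floor lies within the scatter). For compound 3 the estimated value is 220000 nM, with an expected range of 70000 nM to 300000 nM.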

Compound 3, half-maximal cytotoxic concentration: 259000 nM
For compound 3 the middle estimate is 1.2-fold (0.07 log units) below the measured one; the measured number falls inside the stated range.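

In this assay, within the data shown here, compound 3 gives 259000 nM, the first number in this set that is not a limit, so a group on this aromatic carbon can give a readable value. Replacing pyrrolidin-1-yl with pentyloxy gives an at least 1.1-fold lower number from compound 2 to compound 3 (0.06 log units; that floor lies within the scatter), and the comparison with the trifluoroethoxy compound gives an at least 1.1-fold lower number from compound 1 to compound 3 (0.06 log units; that floor lies within the scatter). The step from compound 1 to compound 2 cannot be read, and the rest of the record is a limit: the limit of > 300000 nM in this assay, at which 2 of the 3 values shown sit.

Going by these compounds, the true sizes of both readable steps remain open, as each is given only as a floor. Also open, on these data alone, is whether a shorter alkoxy chain such as ethoxy, a longer one such as octyloxy, or an open-chain amine such as diethylamino on this aromatic carbon gives a number or a limit.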